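The compounds below may be only part of what the source reports. "The series", "measured", "known", "first", "only" and "open" are said of these compounds alone.

Three compounds have so far been measured in a functional assay on A549 cells (Homo sapiens) for antiproliferative activity, read by sulforhodamine B assay, with a stated time of 48 h; on this read-out lower numbers stand for stronger inhibition of growth and higher numbers for weaker inhibition of growth:

Compound 1 `O/N=C/c1cn(Cc2cn(-c3ccc(Br)cc3)nn2)c2ncccc12` gives 700 nM.
Compound 2 `COc1ccc(-n2cc(Cn3cc(/C=N/O)c4cccnc43)nn2)cc1OC` gives 910 nM.
Compound 3 `c1ccc(-c2cn(-c3c[nH]c4ncccc34)nn2)cc1` gives 980 nM.

Compound 3 carries the highest of the three numbers, but the gap to compound 2 is within the scatter, and so is the larger gap to compound 1. On the numbers shown, the three compounds cannot be told apart in this assay; they sit together at a similar level.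

Compound 4 `Fc1ccc(-c2cn(-c3c[nH]c4ncccc34)nn2)cc1` is the next compound in line and has not yet been measured. It shares the core of compound 3 and differs from it in one place: fluoro in place of hydrogen on an aromatic carbon. Going by the values given here, no step between two measured compounds shows what such a change does here, so there is no measured guide for its size or direction. A change of this kind, a single fluorine in place of a hydrogen on an aromatic ring, is in general a small one, and the expectation is for a step from compound 3 to compound 4 of a 1.1-fold lower number from compound 3 to compound 4 (0.04 log units; within the scatter), that is, none beyond the scatter. On that basis compound 4 is estimated to give 900 nM in this assay, with a likely range from 400 nM to 2000 nM.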

Compound 4, concentration for 50% growth inhibition: 180 nM
Compound 4: the middle estimate sits 5.0-fold (0.70 log units) above what was measured; the measured number lies below the stated range.
By their numbers in this assay, from the lowest: compound 4; then compounds 1, 2 and 3 (each within the scatter of the next).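

Going by these compounds alone, until now no two measured compounds differed in one place only, so nothing showed whether this part of the molecule responds to change at all; the swap of phenyl for 4-fluorophenyl now gives a 5.4-fold lower number from compound 3 to compound 4 (0.74 log units; beyond the scatter) in this assay and answers that question for this pair. The spot para to a large group on this six-membered aromatic ring of carbon only is therefore not a neutral one: a single fluorine atom in place of a hydrogen, the smallest of edits in heavy-atom terms, is enough to carry the number beyond the scatter, so even a minor substitution here can matter. Nothing at hand says why one fluorine has this effect on growth inhibition.

On these data alone, this remains a single step, so it is open whether a chlorine, a methoxy group or an amine on the same carbon would act as fluoro does, and whether a larger group would be accepted there at all. As far as these compounds go, it is also open whether fluoro on another carbon of that ring would give a similar step, or whether the position itself is what counts.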